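Adding a chloro group to a piperazine-linked aryl tail

This account rests on a few compounds, and the source may have more. Where it says the series, first, only, none or still open, it means among the compounds named here.

Of the compounds shown here, two have been measured in a functional assay on U-937 cells (Homo sapiens) for cytotoxicity, read by MTT assay, with a stated time of 24 h; on this read-out higher numbers stand for weaker inhibition and lower numbers for stronger inhibition. Going by the values given here, compound 1, `CCN1CCN(CCCSc2nnc(-c3ccc(C)cc3)[nH]2)CC1`, is the first of them. In this assay compound 1 gives > 300000 nM, which is a limit of the assay and not a number. Compound 2, `CC(C)(C)c1ccc(-c2nn(CCCN3CCN(c4ccccc4)CC3)c(=S)[nH]2)cc1`, is the second. In this assay, among the compounds with values here, compound 2 gives 88900 nM, and this is the only actual number among the two values shown.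

Compound 3, `CC(C)(C)c1ccc(-c2nn(CCCN3CCN(c4cccc(Cl)c4)CC3)c(=S)[nH]2)cc1`, has not yet been measured. It differs from compound 2 in one place: chloro in place of hydrogen on an aromatic carbon, the same difference read one bond further out being phenyl to 3-chlorophenyl, with the chloro sitting meta to a large group. Within the data shown here, no pair of measured compounds differing in one place exists here, so no measured step can guide the size of this change. The expected step of a 1.5-fold lower number from compound 2 to compound 3 (0.17 log units; within the scatter) is therefore small, within the usual scatter, with no firm direction. For compound 3 the estimated value in this assay is 60000 nM, with an expected range from 20000 nM to 200000 nM.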

Compound 3, half-maximal inhibitory concentration: > 300000 nM
Compound 3 gave a limit, no number; the forecaster's own chance of this, stated with the estimate: 15%; middle value at least 5.0-fold (0.69 log units) away from the limit.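

Going by these compounds alone, this is the first measured effect of a single change: replacing hydrogen with chloro, turning the phenyl into 3-chlorophenyl, gives an at least 3.3-fold higher number from compound 2 to compound 3 (0.52 log units; beyond the scatter). So this aromatic carbon, meta to a large group, is not a place where the added chlorine leaves the read-out untouched, and here one heavy atom moves the result towards weaker inhibition. In this assay compound 3 gives > 300000 nM, which is a limit of the assay and not a number.

The true size of the step therefore stays unknown, and it could be larger than the printed figure because the value of compound 3 rests on a limit: the limit of > 300000 nM in this assay, at which 2 of the 3 values shown sit.

The compounds shown leave open whether this shift belongs to chloro itself or would also appear with another group in the same place, such as fluoro, methyl or methoxy. Within the data shown here, they also leave open whether a chloro elsewhere on the same phenyl would act in the same way, since this one pair is the only comparison available.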